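Cytotoxicity series: furan-to-catechol-type swap on the amine side

The source may report more compounds than this note shows. Statements on the series, on what has been measured and on what is new or still open speak of the compounds shown alone.

Compound 2 `Fc1ccc(Cc2ccc3c(NCCCNCc4ccco4)ccnc3c2)c(Cl)c1` is the starting point here. For the measured compounds named here, in an ADME assay on HepG2 cells (Homo sapiens) for cytotoxicity, read by luminescence, CellTiter-Glo and ATP content, with a stated time of 72 h (a lower number here means that less compound is needed, a higher number that more compound is needed for the effect), compound 2 gives 5730 nM, the second highest of the three numbers so far. Compound 1 `CC(C)Cc1ccc2c(NCCCNCc3ccco3)ccnc2c1` gives 16000 nM and compound 3 `c1coc(CNCCCNc2ccnc3cc(C4CCCCC4)ccc23)c1` gives 4760 nM; the step of a 2.8-fold lower number from compound 1 to compound 2 (0.45 log units; beyond the scatter) and the step of a 3.4-fold lower number from compound 1 to compound 3 (0.53 log units; beyond the scatter) are modest, whereas the step of a 1.2-fold lower number from compound 2 to compound 3 (0.08 log units; within the scatter) stays within the scatter. All three measured steps alter the group on the aromatic carbon of the shared core, not the amine side.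

Compound 4 `COc1cccc(CNCCCNc2ccnc3cc(Cc4ccc(F)cc4Cl)ccc23)c1O` differs from compound 2 at the other end of the molecule: 2-hydroxy-3-methoxyphenyl in place of furan-2-yl on a saturated chain carbon bound to an amine nitrogen. Going by the values given here, no measured step touches this position, so the change is uncalibrated by the data. Given that the measured steps span only a modest range, with compound 2 at 5730 nM and compound 3 at 4760 nM within scatter of each other, the expectation for compound 4 is a step of a 1.1-fold lower number from compound 2 to compound 4 (0.06 log units; within the scatter) not beyond the scatter. Compound 4 is estimated at 5000 nM, with a range from 2000 nM to 15000 nM.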

Compound 4, half-maximal effective concentration: 2350 nM
The estimate for compound 4 lay 2.1-fold (0.33 log units) above the measured number, and the stated range covers the measured number.
By their numbers in this assay, from the lowest: compound 4; then compounds 3 and 2 (each within the scatter of the next); then compound 1.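

For the compounds shown here, the amine side now proves responsive: in this assay, 2-hydroxy-3-methoxyphenyl in place of furan-2-yl on a saturated chain carbon bound to an amine nitrogen gives a 2.4-fold lower number from compound 2 to compound 4 (0.39 log units; beyond the scatter), the first measured step at this position. This step is modest and beyond the scatter, so the number moves with a change at this end of the molecule as well as with changes on the aromatic carbon. Nothing available here explains the step.

The change replaces the ring and brings in the hydroxy and methoxy groups together, so the step cannot be assigned to any one of these. Open, on these data alone, are how an unsubstituted benzyl, a 2-hydroxybenzyl or a 3-methoxybenzyl group would compare, and whether the same swap gives a similar step on the cyclohexyl-bearing core of compound 3.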